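From Basic Amine to Cyclobutyl Amide on the Ring Nitrogen

The compounds below may be only part of what the source reports. "The series", "measured", "known", "first", "only" and "open" are said of these compounds alone.

Compound 1 `O=C1NCCc2nc(C#Cc3ccccc3)sc21`: 112 nM
Compound 2 `O=C1NCCc2nc(C#Cc3cccc(F)c3)sc21`: 290 nM
Compound 3 `CC(C)CN1CCc2nc(C#Cc3ccccc3)sc2C1`: > 10000 nM

All three were tested in an assay on HEK293 cells for positive allosteric modulation of metabotropic glutamate receptor 5 (Homo sapiens), read by FLIPR, with a stated time of 1 h; a lower number here means that less compound is needed, a higher number that more compound is needed for the effect. Compound 3 gives no number there, only (the limit of > 10000 nM in this assay, at which 1 of the 3 values shown sits). For the measured compounds named here, the only measured step is a 2.6-fold higher number from compound 1 to compound 2 (0.41 log units; beyond the scatter), and it does not touch the ring nitrogen at all.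

Compound 4 `O=C(C1CCC1)N1CCc2nc(C#Cc3ccccc3)sc2C1` differs from compound 3 by cyclobutylcarbonyl in place of isobutyl on an amine nitrogen in a ring. Going by the values given here, no measured step bears on this change, so the expectation rests on the structures alone: compound 1, whose value is a number rather than a limit, carries a carbonyl in its core, as compound 4 would. Compound 4 is therefore expected to give a number in this assay, estimated at 600 nM, within 120 nM to 3000 nM. This estimate means an expected step of an at least 16-fold lower number from compound 3 to compound 4 (1.22 log units; beyond the scatter).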

Compound 4, half-maximal effective concentration: > 10000 nM
Compound 4: no number, only a limit; the forecaster's own chance of this, stated with the estimate: 25%; middle value at least 16-fold (1.22 log units) away from the limit.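

Compound 3 and compound 4 both give only a limit, not a number, so no step between them can be read: the limit of > 10000 nM in this assay, at which 2 of the 4 values shown sit.

The compounds shown leave open whether cyclobutylcarbonyl in place of isobutyl on an amine nitrogen in a ring changes the result at all.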